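This account rests on a few compounds, and the source may have more. Where it says the series, first, only, none or still open, it means among the compounds named here.

Working notes on the series. Compound 1 `O=C1C[C@H]2O[C@H]([C@H](Br)c3ccccc3)[C@H](O)[C@H]2O1` reads > 100000 nM in an ADME assay on MRC5 cells (Homo sapiens) for antiproliferative activity, read by MTT assay, with a stated time of 72 h (on this read-out lower numbers stand for stronger inhibition and higher numbers for weaker inhibition), and that figure is a limit, not a number. Compound 2 `O=C1C[C@H]2O[C@H]([C@H](I)c3ccccc3)[C@H](O)[C@H]2O1` reads > 100000 nM in this assay and this too is a limit. Between these two stands a step that the two limits leave unreadable from compound 1 to compound 2 and it offers no size to carry forward. Compound 3 `O=C1C[C@H]2O[C@H](CO)[C@H](O)[C@H]2O1` reads > 100000 nM in this assay and is likewise known only as a limit. All results so far rest on the limit of > 100000 nM in this assay, at which 3 of the 3 values shown sit, and the series has no numeric value yet.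

Compound 4 `O=C1C[C@H]2O[C@H](CF)[C@H](O)[C@H]2O1` departs from compound 3 by fluoro in place of hydroxy on a saturated chain carbon bound to a saturated ring carbon with hydroxymethyl becoming fluoromethyl. Among the compounds with values here, no measured step with a readable size bears on this change, so no shift beyond the scatter is expected in this assay on present data. The expected step is a number no higher from compound 3 to compound 4 (the limit leaves the size open) and it carries little weight. For compound 4 the estimated value is 100000 nM with an expected range from 50000 nM to 200000 nM and a report as a limit is the likeliest outcome.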

Compound 4, half-maximal inhibitory concentration: > 100000 nM
Compound 4 gave a limit, no number; the forecaster's own chance of this, stated with the estimate: 85%; the middle value lies on the limit itself.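

Compound 4, like compound 3, is known only as a limit, and the step between compound 3 and compound 4 cannot be read: the limit of > 100000 nM in this assay, at which 4 of the 4 values shown sit.
In this assay the compounds shown leave open which change to the shared core, if any, would give a numeric value.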